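Swapping phenylsulfonyl for phenyl on an amine nitrogen

The source may report more compounds than this note shows. Statements on the series, on what has been measured and on what is new or still open speak of the compounds shown alone.

Compound 1, `O=C1Nc2ccc(S(=O)(=O)N3CCOCC3)cc2/C1=N/NS(=O)(=O)c1ccccc1`, was tested in a functional assay on HepG2 cells (Homo sapiens) for cytotoxicity, read by sulforhodamine B assay, with a stated time of 24 h (on this read-out lower numbers stand for stronger inhibition and higher numbers for weaker inhibition), where compound 1 gives 23900 nM. Going by the values given here, of the two compounds measured so far, compound 1 shows the lowest number, though this carries little weight, since its only neighbour sits within the scatter. That neighbour is compound 2, `CC(=O)N/N=C1\C(=O)Nc2ccc(S(=O)(=O)N3CCOCC3)cc21`, which in this assay gives 27500 nM. The step of a 1.2-fold higher number from compound 1 to compound 2 (0.06 log units; within the scatter) shows that replacing one group on that amine nitrogen with a much smaller one left the cytotoxicity essentially where it was.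

Compound 3, `O=C1Nc2ccc(S(=O)(=O)N3CCOCC3)cc2/C1=N/Nc1ccccc1`, has not yet been measured. It differs from compound 1 in one place: phenyl in place of phenylsulfonyl on an amine nitrogen. Among the compounds with values here, the single measured step that touches the same amine nitrogen is the one just described, and it stayed within the scatter. On that basis no step beyond the scatter is expected in this assay in either direction. The change is thus expected to amount to a 1.1-fold lower number from compound 1 to compound 3 (0.04 log units; within the scatter). Compound 3 is accordingly estimated to give about 22000 nM, with a likely range from 8000 nM to 60000 nM.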

Compound 3, half-maximal inhibitory concentration: 15600 nM
Estimate against measurement, compound 3: 1.4-fold (0.15 log units) above; the range from low to high includes it.
By their numbers in this assay, from the lowest: compounds 3, 1 and 2 (each within the scatter of the next).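

With a third group in place, this amine nitrogen has now carried phenylsulfonyl, acetyl and phenyl, and in this assay every step among them stays within the scatter: phenyl for phenylsulfonyl gives (a 1.5-fold lower number from compound 1 to compound 3 (0.19 log units; within the scatter)), and phenyl for acetyl gives (a 1.8-fold lower number from compound 2 to compound 3 (0.25 log units; within the scatter)). Going by these compounds alone, the earlier pair showed only that one group containing a carbonyl could stand in for phenylsulfonyl, whereas this result adds a plain aromatic ring with 0 hydrogen-bond acceptors against the 2 of phenylsulfonyl, and the numbers still cannot be told apart, so the sulfonyl link is not needed at this position to keep the read-out in this range. No measurement on hand accounts for this tolerance.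

What the three compounds leave open is whether any group on this nitrogen can move the number beyond the scatter, for instance a carboxylic acid, an amine or a longer alkyl chain, or a phenyl ring carrying a chlorine. On these data alone, the shared core is also identical throughout, so its own part in the cytotoxicity remains untested here.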